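Propyl for isopropyl: one repeated step in the series

The compounds below may be only part of what the source reports. "The series", "measured", "known", "first", "only" and "open" are said of these compounds alone.

Measured compounds:
compound 1 `COc1cc(N(C)CCN(C)C)c(NC(=O)/C=C\C(C)C)cc1Nc1ncc(C#N)c(-c2cn(C)c3ccccc23)n1`: 1810 nM
compound 2 `CCC/C=C\C(=O)Nc1cc(Nc2ncc(C#N)c(-c3cn(C)c4ccccc34)n2)c(OC)cc1N(C)CCN(C)C`: 1690 nM
compound 3 `COc1cc(N(C)CCN(C)C)c(NC(=O)/C=C\C(C)C)cc1Nc1nc(C)cc(-c2cn(C)c3ccccc23)n1`: 3550 nM

In a functional assay on HepG2 cells (Homo sapiens) for antiproliferative activity, read by MTT assay, with a stated time of 72 h (on this read-out lower numbers stand for stronger inhibition and higher numbers for weaker inhibition), compound 1 gives 1810 nM, compound 2 gives 1690 nM and compound 3 gives 3550 nM. Compound 1 and compound 2 are separated by propyl in place of isopropyl on a double-bonded chain carbon bound to a double-bonded chain carbon, and that change made a 1.1-fold lower number from compound 1 to compound 2 (0.03 log units; within the scatter). Compound 3 and compound 1 differ in their cores; that difference is not broken down here, and their two values lie within the usual scatter of each other, while the gap from compound 3 to compound 2 lies beyond it.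

Compound 4 `CCC/C=C\C(=O)Nc1cc(Nc2nc(C)cc(-c3cn(C)c4ccccc34)n2)c(OC)cc1N(C)CCN(C)C` is not yet measured. It stands to compound 3 exactly as compound 2 stands to compound 1: propyl in place of isopropyl on a double-bonded chain carbon bound to a double-bonded chain carbon, the same change at the same place. For compound 4 the step in this assay is expected to be a 1.1-fold lower number from compound 3 to compound 4 (0.03 log units; within the scatter), beside the earlier 1.1-fold lower number from compound 1 to compound 2 (0.03 log units; within the scatter), resting on that single measured pair alone. Compound 4 is therefore estimated at 3300 nM, with a likely range from 1600 nM to 7000 nM.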

Compound 4, half-maximal inhibitory concentration: 365 nM
Compound 4: the middle estimate sits 9.0-fold (0.96 log units) above what was measured, outside the stated range (below it).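

Propyl in place of isopropyl on a double-bonded chain carbon bound to a double-bonded chain carbon gives a 9.7-fold lower number from compound 3 to compound 4 (0.99 log units; beyond the scatter) in this assay, and the step does not carry over unchanged between the two cores: the same change on two cores in this assay, a 1.1-fold lower number (0.03 log units; within the scatter) from compound 1 to compound 2 and a 9.7-fold lower number (0.99 log units; beyond the scatter) from compound 3 to compound 4, 9.1-fold (0.96 log units) apart, beyond the scatter of two such steps

The size of this change therefore cannot be assumed to transfer from one core to another in this series. Among the compounds shown here, two pairs show only that the step can differ; they do not show which feature of the cores goes with the difference, nor give a rule for any third core.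

Still open, going by these compounds, is how a butyl chain or a cyclopropyl group at this place would compare with propyl and isopropyl on each core. Also open, on these data alone, is whether a further core would follow compound 2 or compound 4.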